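Toward a chloromethylphenyl analogue of compound 2

This account rests on a few compounds, and the source may have more. Where it says the series, first, only, none or still open, it means among the compounds named here.

Three compounds built on a shared core have been examined in a functional assay on HEK293 cells for agonist activity at D(4) dopamine receptor (Homo sapiens), read by FLIPR; on this read-out higher numbers stand for larger maximal responses and lower numbers for smaller maximal responses. Compound 1 `COc1ccccc1C1CCN(CC(=O)Nc2cccc(C)c2)CC1` gives 43% in this assay. Compound 2 `Cc1cc(C)cc(NC(=O)CN2CCC(c3cccc[n+]3[O-])CC2)c1` gives 76%, and compound 3 `O=C(NCN1CCC(c2cccc[n+]2[O-])CC1)c1ccc(F)c(Cl)c1` gives 67%. Among these three numbers compound 2 stands highest; its gap to compound 3 lies within the scatter of repeated measurements, so no order between those two can be claimed, whereas its gap to compound 1 lies beyond the scatter.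

Compound 4 `Cc1ccc(Cl)cc1NC(=O)CN1CCC(c2cccc[n+]2[O-])CC1` has not yet been measured. It differs from compound 2 in one place only: 5-chloro-2-methylphenyl in place of 3,5-dimethylphenyl on an amide-type nitrogen. The group that enters and the group that leaves match in heavy-atom count, in having one six-membered aromatic ring of carbon only, and in carrying no donors, acceptors or charge.

Going by the values given here, no measured pair shows exactly this exchange. The values of compound 2 and compound 3 show that a change on the amide side can leave the response within the scatter. The step from compound 2 to compound 4 in this assay is therefore expected to be small, a number 10 percentage points lower from compound 2 to compound 4 (within the scatter), pointing slightly downward or not beyond the scatter. Compound 4 is estimated at 66%, within a range from 45% to 85%.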

Compound 4, largest response reached (reported as efficacy), in percent of the reference or control that the assay uses: 58%
Compound 4: the middle estimate sits 8 percentage points above what was measured; the measured number falls inside the stated range.
By their numbers in this assay, from the lowest: compound 1; then compounds 4, 3 and 2 (each within the scatter of the next, the first and the last beyond it).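

In this assay, going by these compounds alone, placing 5-chloro-2-methylphenyl in place of 3,5-dimethylphenyl on the amide-type nitrogen gives a number 18 percentage points lower from compound 2 to compound 4 (beyond the scatter), the first step here between compounds that differ in one place. The response at this position therefore depends on more than the features the two groups share, since they match in heavy-atom count, in having one six-membered aromatic ring of carbon only, and in carrying no donors, acceptors or charge. The data offer no measurement that accounts for this step.

The compounds shown do not separate the contribution of the chlorine from that of the different arrangement of groups on the ring, so the step cannot be assigned to either one. Also open, from the compounds shown here alone, is how the response would run with a nitrile or an amine on the ring in place of the chlorine, and whether the same exchange would give a step of similar size on another core.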